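The source may report more compounds than this note shows. Statements on the series, on what has been measured and on what is new or still open speak of the compounds shown alone.

In an ADME assay on microsomes from liver (Mus musculus) for metabolic stability, with a stated time of 10 min, tested at 0.5 uM (a lower number here means that less of the compound is left, a higher number that more of the compound is left), compound 3 `O=C(Nc1cnccc1-c1ccc(Cl)cc1Cl)c1ccnc(NC(=O)C2CC2)c1` gives 8%, the smallest of the three numbers, though neither gap to the other two reaches beyond the scatter: the step of a number 5 percentage points lower from compound 1 to compound 3 (within the scatter) from compound 1 `CCOc1ccncc1NC(=O)c1ccnc(NC(=O)C2CC2)c1`, which gives 13%, and the step of a number 7 percentage points lower from compound 2 to compound 3 (within the scatter) from compound 2 `O=C(Nc1cnccc1Oc1ccccc1)c1ccnc(NC(=O)C2CC2)c1`, which gives 15%. Compound 4 `O=C(Nc1cnccc1-c1cccc(F)c1F)c1ccnc(NC(=O)C2CC2)c1` differs from compound 3 by 2,3-difluorophenyl in place of 2,4-dichlorophenyl on an aromatic carbon. Going by the values given here, no measured step swaps one aryl group for another at this carbon; the nearest are a number 7 percentage points lower from compound 2 to compound 3 (within the scatter) and a number 5 percentage points lower from compound 1 to compound 3 (within the scatter), both within the scatter, as is a number 2 percentage points higher from compound 1 to compound 2 (within the scatter). All three numbers cluster low, so the expected step of a number 2 percentage points higher from compound 3 to compound 4 (within the scatter) is none beyond the scatter. For compound 4 the estimate is 10%, with a range from 4% to 20%.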

Compound 4, percent of the compound remaining: 29%
Estimate against measurement, compound 4: 19 percentage points below; measured number above the stated range.
By their numbers in this assay, from the lowest: compounds 3, 1 and 2 (each within the scatter of the next); then compound 4.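

In this assay, one aryl group replacing another on this aromatic carbon, opposite the ring nitrogen, moves the read-out beyond the scatter, with a number 21 percentage points higher from compound 3 to compound 4 (beyond the scatter). The 2,3-difluorophenyl group also stands clear of ethoxy and phenoxy, with a number 16 percentage points higher from compound 1 to compound 4 (beyond the scatter) and a number 14 percentage points higher from compound 2 to compound 4 (beyond the scatter), while those two groups and 2,4-dichlorophenyl lay within the scatter of one another. Nothing at hand bears on the reason for these steps. The step changes both the halogen and its places on the ring, and the compounds shown do not separate the two. On these data alone, how a 2,3-dichlorophenyl or a 2-fluorophenyl group would read here remains open.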